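The compounds below may be only part of what the source reports. "The series", "measured", "known", "first", "only" and "open" are said of these compounds alone.

Compound 1 `CNC(=O)[C@@]12C[C@@H]1[C@@H](n1cnc3cnc(C#Cc4ccc(Cl)s4)nc31)[C@H](O)[C@@H]2O` gives 60 nM in an assay on CHO cells for displacement of a labelled ligand from transmembrane domain-containing protein TMIGD3 (Homo sapiens), read by scintillation counting, with a stated time of 60 min; on this read-out lower numbers stand for stronger inhibition and higher numbers for weaker inhibition.
Compound 2 `CNC(=O)[C@@]12C[C@@H]1[C@@H](n1cnc3cnc(/C=C(\O)c4cnccn4)nc31)[C@H](O)[C@@H]2O` gives 1480 nM in this assay.

Among the compounds with values here, of these two numbers, compound 2 stands highest, so in this assay it is the weaker binder; its nearest neighbour is compound 1, and the only measured step, a 25-fold higher number from compound 1 to compound 2 (1.39 log units; beyond the scatter), shows how much was lost when an ethynyl-linked ring was exchanged for the hydroxy ethenyl group. Compound 3 `CNC(=O)[C@@]12C[C@@H]1[C@@H](n1cnc3cnc(C#Cc4ccc(F)c(F)c4)nc31)[C@H](O)[C@@H]2O` reverses that kind of change: 2-(3,4-difluorophenyl)ethynyl in place of 2-hydroxy-2-(pyrazin-2-yl)ethenyl on an aromatic carbon. Because a 25-fold higher number from compound 1 to compound 2 (1.39 log units; beyond the scatter) was large, and compound 3 carries an ethynyl-linked aromatic ring again as compound 1 does, the step is expected to run strongly downward, a 15-fold lower number from compound 2 to compound 3 (1.17 log units; beyond the scatter). The two rings on the ethynyl link are not the same, so the number is not expected to match that of compound 1 exactly. Compound 3 is therefore estimated at 100 nM, with a range from 30 nM to 400 nM.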

Compound 3, inhibition constant: 124 nM
Compound 3: middle estimate off by 1.2-fold (0.09 log units), on the low side, and the stated range covers the measured number.
By their numbers in this assay, from the lowest: compound 1; then compound 3; then compound 2.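

In this assay, a triple-bonded aromatic ring on this aromatic carbon of the shared core recovers most of the ground lost with the hydroxy ethenyl group, with a 12-fold lower number from compound 2 to compound 3 (1.08 log units; beyond the scatter) and this large change replacing both the link and the ring at once. Compared with that, exchanging one ring on the triple bond for another has a much smaller effect: 3,4-difluorophenyl in place of 5-chlorothiophen-2-yl gives a 2.1-fold higher number from compound 1 to compound 3 (0.32 log units; beyond the scatter), a modest step that is still beyond the scatter. Nothing measured here explains either step.

Within the data shown here, how much of the recovery belongs to the triple bond and how much to the ring remains open, since no compound changes one without the other. Also open, from the compounds shown here alone, is how a non-aromatic group on the triple bond, such as a dimethylaminomethyl group or a carboxylic acid, would compare with these rings.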